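This account rests on a few compounds, and the source may have more. Where it says the series, first, only, none or still open, it means among the compounds named here.

Measured compounds, half-life in an in vitro ADME assay on microsomes from liver (Rattus norvegicus) for metabolic stability, read by LC-MS, using NADPH, tested at 1 uM; a higher number here means that the compound lasts longer, a lower number that the compound disappears faster:

compound 3 `CN1C(=O)CN(Cc2ccc(-c3cccc(CN4CCCCC4)n3)cc2)C1=O`: 1.5 h
compound 1 `CCN1C(=O)CN(Cc2ccc(-c3cccc(CN4CCCCC4)n3)cc2)C1=O`: 0.95 h
compound 2 `CC(C)CN1C(=O)CN(Cc2ccc(-c3ccc(F)c(CN4CCCCC4)n3)cc2)C1=O`: 0.15 h

Compound 3 carries the highest number of the three in this assay, but its gap to compound 1 is within the scatter; only compound 2 lies clearly lower. Compound 2 differs from compound 3 in two places at once, so its value says nothing on its own about the ring nitrogen substituent.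

Compound 4 `O=C1CN(Cc2ccc(-c3cccc(CN4CCCCC4)n3)cc2)C(=O)N1C1CC1` is not yet measured. It differs from compound 3 by cyclopropyl in place of methyl on an amide-type nitrogen in a ring.

Among the measured compounds shown here, the one step that bears on this position is a 1.6-fold higher number from compound 1 to compound 3 (0.20 log units; within the scatter), which runs from ethyl to methyl and stays within the scatter. Cyclopropyl is larger than methyl, in the direction of ethyl rather than of hydrogen, so the step to compound 4 is expected to be small and, if anything, downward, on the pattern of compound 1 giving 0.95 h against compound 3 giving 1.5 h. The expected step is a 1.5-fold lower number from compound 3 to compound 4 (0.18 log units; within the scatter).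

For compound 4 in this assay the estimate is 1 h, with a range from 0.5 h to 2 h.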

Compound 4, half-life in the Rattus norvegicus assay: 1.42 h
Compound 4: middle estimate off by 1.4-fold (0.15 log units), on the low side; the measured number falls inside the stated range.
By their numbers in the Rattus norvegicus assay, from the lowest: compound 2; then compounds 1, 4 and 3 (each within the scatter of the next).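

Placing cyclopropyl on the amide-type nitrogen gives, in the Rattus norvegicus assay, a 1.1-fold lower number from compound 3 to compound 4 (0.02 log units; within the scatter) and a 1.5-fold higher number from compound 1 to compound 4 (0.17 log units; within the scatter) as the two new steps at this position. The earlier compounds shown here gave a clean comparison of methyl and ethyl only; a three-membered ring now stands on this nitrogen, and no step among methyl, ethyl and cyclopropyl lies beyond the scatter in half-life. In a physicochemical assay for acid dissociation, compound 3 gives 8.7 and compound 4 gives 9 with the two within the scatter of each other, so the change separates these compounds in neither read-out.

From the compounds shown here alone, it remains open whether a chain ending in an amine or a carboxylic acid on this nitrogen would shift the half-life beyond the scatter, and how the low number of compound 2 divides between its two differences from compound 3. Nothing available here explains why these substituents leave the half-life within the scatter.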